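Cyclohexyl for cyclopentylmethyl in compound 3

The compounds below may be only part of what the source reports. "The series", "measured", "known", "first", "only" and "open" are said of these compounds alone.

In an ADME assay on NIH3T3 cells (Mus musculus) for cytotoxicity (on this read-out lower numbers stand for higher toxicity in this test and higher numbers for lower toxicity in this test), compound 1 `CC(C)CN(NC(=O)C1CCC2(CC1)OOC1(OO2)C2CC3CC(C2)CC1C3)c1nc(C#N)ncc1Br` gives 8000 nM and compound 2 `N#Cc1ncc(Br)c(N(CC2CCCC2)NC(=O)C2CCC3(CC2)OOC2(OO3)C3CC4CC(C3)CC2C4)n1` gives 5500 nM, so the two stand within the scatter of each other. Compound 3 `N#Cc1ncc(Br)c(N(NC(=O)C2CCC3(CC2)OOC2(OO3)C3CC4CC(C3)CC2C4)C2CCCCC2)n1` has cyclohexyl in place of cyclopentylmethyl on a nitrogen on an aromatic ring. For the measured compounds named here, the only measured step, a 1.5-fold lower number from compound 1 to compound 2 (0.16 log units; within the scatter), came with cyclopentyl in place of isopropyl on a saturated chain carbon and stayed within the scatter, so nothing beyond the scatter is expected here, in either direction. For compound 3 the expected step is no change at the digits printed from compound 2 to compound 3 (within the scatter). Compound 3 is estimated at 5500 nM, with an expected range of 2500 nM to 12000 nM.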

Compound 3, half-maximal cytotoxic concentration: 1400 nM
Beside the measured number, compound 3's estimate is 3.9-fold (0.59 log units) above it; the measured number lies below the stated range.
By their numbers in this assay, from the lowest: compound 3; then compounds 2 and 1 (each within the scatter of the next).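

Cyclohexyl in place of cyclopentylmethyl on this nitrogen gives a 3.9-fold lower number from compound 2 to compound 3 (0.59 log units; beyond the scatter) in this assay, although both groups hold the same atoms, so this position responds to how those carbons are joined, which the earlier change on the chain carbon did not show. Cyclohexyl in place of isobutyl gives a 5.7-fold lower number from compound 1 to compound 3 (0.76 log units; beyond the scatter), a step in the same direction. No evidence is available to explain these steps. Going by these compounds, whether cyclopentyl or a longer chain on this nitrogen would give a similarly low number stays open.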